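The source may hold more compounds than are shown below. What is called first, only, known or untested is meant among the compounds shown, and "the series" means these compounds.

Measured so far in a functional assay on DU-145 cells (Homo sapiens) for inhibition, read by sulforhodamine B assay, with a stated time of 48 h; a higher number here means a weaker inhibitor of growth, a lower number a stronger inhibitor of growth:
compound 1 `Nc1cc(N)c2nc(-c3ccccc3)c(NCc3ccc(F)cc3)nc2c1` gives 3800 nM
compound 2 `COc1ccc(CNc2nc3cc(N)cc(N)c3nc2-c2ccccc2)cc1` gives 57500 nM
compound 3 `COc1ccc(Sc2nc3cc(N)cc(N)c3nc2-c2ccccc2)cc1` gives 33100 nM

Among these three numbers compound 3 stands second highest. Its nearest neighbour is compound 2, and the two lie within the scatter of each other, so nothing separates them. Compound 1 lies well apart, as the step of an 8.7-fold higher number from compound 1 to compound 3 (0.94 log units; beyond the scatter) shows.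

Compound 4 `Nc1cc(N)c2nc(-c3ccccc3)c(Oc3ccc(F)cc3)nc2c1` changes the group that hangs on the core of compound 3: 4-fluorophenoxy in place of (4-methoxyphenyl)sulfanyl on an aromatic carbon. Two things shift at once. The first, fluoro for methoxy on the outer ring, has a measured counterpart: the step of a 15-fold higher number from compound 1 to compound 2 (1.18 log units; beyond the scatter) went the other way, methoxy for fluoro, and gave a large rise. Reversed, it points to a clear fall. Among the compounds with values here, the second, an oxy link for a sulfanyl link, has no measured counterpart here, which widens the uncertainty. A fall beyond the scatter is therefore expected. Compound 4 is expected to give about 8000 nM, between 2500 nM and 25000 nM, a step of a 4.1-fold lower number from compound 3 to compound 4 (0.62 log units; beyond the scatter).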

Compound 4, concentration for total growth inhibition: 87100 nM
Beside the measured number, compound 4's estimate is 11-fold (1.04 log units) below it; measured number outside the range, above it.
By their numbers in this assay, from the lowest: compound 1; then compounds 3, 2 and 4 (each within the scatter of the next, the first and the last beyond it).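

Changing to 4-fluorophenoxy gives a 2.6-fold higher number from compound 3 to compound 4 (0.42 log units; beyond the scatter) so a fluoro on the outer ring does not by itself bring the number down. Keeping the fluoro but replacing the (4-fluorobenzyl)amino group with 4-fluorophenoxy gives a 23-fold higher number from compound 1 to compound 4 (1.36 log units; beyond the scatter) and compound 2, with the same amino link but methoxy in place of fluoro, also lies well above compound 1, so among these four compounds only that link paired with fluoro gives the low number. Nothing measured here accounts for this.

The compounds shown cannot separate the effect of the link from that of the outer-ring group in the step to compound 4, which a 4-methoxyphenoxy or a (4-fluorophenyl)sulfanyl group could do. As far as these compounds go, how much the low number depends on the exact group also stays open, for instance with a chloro on the outer ring or a longer chain between the amine and that ring.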